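A Sulfonyl Aryl Swap Repeated on a Second Core

The source may hold more compounds than are shown below. What is called first, only, known or untested is meant among the compounds shown, and "the series" means these compounds.

Measured compounds:
Compound 1 `COc1ccc(S(=O)(=O)c2cnc3cc(Cl)ccc3c2N2CCC(C)CC2)cc1Cl` gives 93% in an assay on isolated protein for displacement of a labelled ligand from metabotropic glutamate receptor 5 (Homo sapiens), with a stated time of 60 min, tested at 1 uM; on this read-out lower numbers stand for less inhibition and higher numbers for more inhibition at the one concentration tested (going by the name of the read-out).
Compound 2 `Cc1ccc(S(=O)(=O)c2cnc3cc(Cl)ccc3c2N2CCC(C)CC2)cc1` gives 94% in this assay.
Compound 3 `COc1ccc(S(=O)(=O)c2cnc3ccc(F)cc3c2N2CCC(C)CC2)cc1Cl` gives 82% in this assay.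

Compounds 1 and 2 share one core and differ only in the group on the sulfonyl sulfur: 4-methylphenyl in place of 3-chloro-4-methoxyphenyl on a sulfonyl sulfur. In this assay this change makes a number 1 percentage points higher from compound 1 to compound 2 (within the scatter), so the two compounds are not separated by this read-out.

Compound 3 carries a different core. How the core of compound 3 differs from the core of compound 1 is not broken down here. In this assay compound 3 gives the lowest of the three numbers, and its distance to compound 1 and to compound 2 lies beyond the usual scatter in each case.

Compound 4 `Cc1ccc(S(=O)(=O)c2cnc3ccc(F)cc3c2N2CCC(C)CC2)cc1` has not yet been measured. It stands to compound 3 as compound 2 stands to compound 1: 4-methylphenyl in place of 3-chloro-4-methoxyphenyl on a sulfonyl sulfur. The place of the change reads the same in both pairs, so it is the same change on another core.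

Among the measured compounds shown here, the single measured instance of this change, from compound 1 to compound 2, is within the scatter. On that basis the step from compound 3 to compound 4 in this assay is expected to be a number 1 percentage points higher from compound 3 to compound 4 (within the scatter). Compound 4 is therefore estimated to give 83% in this assay, with a likely range from 70% to 93%.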

Compound 4, a percentage reported as inhibition, at one concentration (the size of the read-out at that concentration, not a potency): 91%
For compound 4 the middle estimate is 8 percentage points below the measured one, and the stated range covers the measured number.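

Carried onto the second core, the swap of 3-chloro-4-methoxyphenyl for 4-methylphenyl on a sulfonyl sulfur gives, in this assay, a number 9 percentage points higher from compound 3 to compound 4 (within the scatter) and so stays within the scatter on this core as well. Set side by side, the two steps cannot be told apart, which means that in this small set the change reads the same on both cores: the same change on two cores in this assay, a number 1 percentage points higher (within the scatter) from compound 1 to compound 2 and a number 9 percentage points higher (within the scatter) from compound 3 to compound 4, 8 percentage points apart, within the scatter of two such steps. This does not show that the change has no effect or that the two steps are truly equal, since the read-out gives the size of inhibition at one concentration and not a potency, and any real difference smaller than the scatter would go unseen. Two pairs on two cores also say nothing about a third core, and the swap alters the chloro and methoxy groups together with the methyl group, so the part played by each remains unresolved.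

The compounds shown leave open whether the same agreement would hold for other groups on the sulfonyl sulfur, such as a longer alkyl chain or a phenyl ring carrying an amine or a carboxylic acid. They also leave open how these compounds would compare in a full concentration series.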